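Longer nitrile chains on a leukotriene receptor ligand

A few compounds are considered here, and "the series" means these few. Any claim that something is new, unique, unknown or untested is made for them only; others in the source may bear on it.

Compound 1, `CCc1cc(C(C)=O)c(O)cc1OCCCCC#N`: 92%
Compound 2, `CCc1cc(C(C)=O)c(O)cc1OCCCC(C)(C)C#N`: 85%
Compound 3, `CCc1cc(C(C)=O)c(O)cc1OCCCCCC(C)(C)C#N`: 85%

In an assay on isolated protein for inhibition of leukotriene B4 receptor 1 (Homo sapiens), tested at 10 uM (a lower number here means less inhibition, a higher number more inhibition at the concentration tested (going by the name of the read-out)), compound 3 stands level with compound 2, the two sharing the lowest of the three numbers, while compound 1 sits close by, the step being a number 7 percentage points lower from compound 1 to compound 3 (within the scatter). Compound 4, `CCc1cc(C(C)=O)c(O)cc1OCCCCCCC(C)(C)C#N`, is the next compound; its difference from compound 3 is 2-cyano-2-methylpropyl in place of 1-cyano-1-methylethyl on a saturated chain carbon, five bonds along the chain from an oxygen on an aromatic ring. Among the measured compounds shown here, the steps that bear on this are no change at the digits printed from compound 2 to compound 3 (within the scatter) and a number 7 percentage points lower from compound 1 to compound 3 (within the scatter), neither of which moved the read-out beyond the scatter. A further change of this kind is therefore expected to leave the read-out where it is, with an expected step of a number 1 percentage points lower from compound 3 to compound 4 (within the scatter). Compound 4 is estimated at 84%, with a range from 70% to 95%.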

Compound 4, a percentage reported as inhibition, at one concentration (the size of the read-out at that concentration, not a potency): 65%
The estimate for compound 4 lay 19 percentage points above the measured number; the whole stated range lies above it.
By their numbers in this assay, from the lowest: compound 4; then compounds 2, 3 and 1 (each within the scatter of the next).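

Replacing 1-cyano-1-methylethyl with 2-cyano-2-methylpropyl at this place gives a number 20 percentage points lower from compound 3 to compound 4 (beyond the scatter) in this assay, which shows that the chain cannot be lengthened without limit. The shorter chains tell the same story, with a number 20 percentage points lower from compound 2 to compound 4 (beyond the scatter) and a number 27 percentage points lower from compound 1 to compound 4 (beyond the scatter). Compound 4 alone separates from the others, whereas compound 1, compound 2 and compound 3 remain within the scatter of one another.

No measurement shown explains this fall. As far as these compounds go, whether a longer chain lowers the number further, or a carboxylic acid in place of the nitrile restores it, remains open.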